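The source may report more compounds than this note shows. Statements on the series, on what has been measured and on what is new or still open speak of the compounds shown alone.

Compound 1, `CN(C)c1ccc2cc(NC(=O)CCc3ccc(C(F)(F)F)cc3)ccc2n1`: 13 nM
Compound 2, `Nc1ccc2cc(NC(=O)CCc3ccc(C(F)(F)F)cc3)ccc2n1`: 240 nM
Compound 3, `O=C(CCc1ccc(C(F)(F)F)cc1)Nc1ccc2nc(N3CCC3)ccc2c1`: 4 nM

These three share one core and differ only in the group on one aromatic carbon. In an assay on isolated protein for displacement of a labelled ligand from melanin-concentrating hormone receptor 1 (Homo sapiens) (on this read-out higher numbers stand for weaker inhibition and lower numbers for stronger inhibition), compound 3 gives the lowest number of the three, as shown by a 3.3-fold lower number from compound 1 to compound 3 (0.51 log units; beyond the scatter) and a 60-fold lower number from compound 2 to compound 3 (1.78 log units; beyond the scatter). Compound 4, `CC(C)C(=O)NC1CCN(c2ccc3cc(NC(=O)CCc4ccc(C(F)(F)F)cc4)ccc3n2)C1`, brings (3-((isopropylcarbonyl)amino)pyrrolidin-1-yl in place of azetidin-1-yl on an aromatic carbon). For the measured compounds named here, both measured steps onto compound 3 went from a smaller nitrogen substituent to the azetidine and lowered the number; no measured step goes from the azetidine to a larger ring, so the change toward compound 4 has no direct precedent. The expectation is a step no larger than the scatter, leaning slightly upward: a 1.8-fold higher number from compound 3 to compound 4 (0.24 log units; within the scatter). Compound 4 is estimated at 7 nM (range 1.5 nM to 30 nM).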

Compound 4, half-maximal inhibitory concentration: 1 nM
Compound 4: middle estimate off by 7.0-fold (0.85 log units), on the high side; measured number below the stated range.
By their numbers in this assay, from the lowest: compound 4; then compound 3; then compound 1; then compound 2.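

The position next to the ring nitrogen accepts far more than the small groups seen earlier: in this assay, 3-((isopropylcarbonyl)amino)pyrrolidin-1-yl, with 11 heavy atoms against 4 in azetidin-1-yl, gives (a 4.0-fold lower number from compound 3 to compound 4 (0.60 log units; beyond the scatter)). The same group also gives (a 13-fold lower number from compound 1 to compound 4 (1.11 log units; beyond the scatter)) and (a 240-fold lower number from compound 2 to compound 4 (2.38 log units; beyond the scatter)), so compound 4 has the lowest number of the four. No measurement shown explains this gain.

Going by these compounds, the new group changes both the ring and its side chain, so the contribution of each stays open. An unsubstituted pyrrolidin-1-yl, or the same ring carrying a free amine, would separate the two.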